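The source may hold more compounds than are shown below. What is called first, only, known or untested is meant among the compounds shown, and "the series" means these compounds.

Compound 1 `COc1ccc(S(=O)(=O)N(C)CCOCC(=O)N(C)Cc2ccc(C3=NCCN3)cc2)c(C)c1`: 8.6
Compound 2 `CN(Cc1ccc(C2=NCCN2)cc1)C(=O)COCCN(C)S(=O)(=O)c1ccc(OC(F)(F)F)cc1`: 7.5

In a functional assay on Umbilical vein for antagonist activity at B1 bradykinin receptor (Homo sapiens), using Schild analysis, with a stated time of 30 min (a higher number here means a more potent compound, by a factor of ten per unit of this negative logarithm, a lower number a less potent compound), compound 2 gives 7.5, the lower of the two numbers, while compound 1 gives 8.6. Going by the values given here, the only measured step, a number 1.10 log units lower from compound 1 to compound 2 (beyond the scatter), swapped the aryl group on the sulfonyl sulfur. Compound 3 `CN(Cc1ccc(C2=NCCN2)cc1)C(=O)COCCN(C)S(=O)(=O)c1c(F)cccc1F` changes that same position again: 2,6-difluorophenyl in place of 4-(trifluoromethoxy)phenyl on a sulfonyl sulfur. Among the compounds with values here, because that earlier step a number 1.10 log units lower from compound 1 to compound 2 (beyond the scatter) was large, a shift of similar size is plausible here, and the direction is uncertain since no measured compound carries a 2,6-difluorophenyl. Compound 3 is therefore expected at 8, within 7.2 to 8.8, a step of a number 0.50 log units higher from compound 2 to compound 3 (beyond the scatter).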

Compound 3, negative logarithm of the antagonist equilibrium constant: 7.6
Compound 3: middle estimate off by 0.40 log units, on the high side; measured number inside the range.
By their numbers in this assay, from the lowest: compounds 2 and 3 (each within the scatter of the next); then compound 1.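

Putting 2,6-difluorophenyl in place of 4-(trifluoromethoxy)phenyl on the sulfonyl sulfur gives no real separation in this assay, with a number 0.10 log units higher from compound 2 to compound 3 (within the scatter), so these two differently substituted groups cannot be told apart here. The 4-methoxy-2-methylphenyl group still stands apart from the 2,6-difluorophenyl group, with a number 1.00 log units lower from compound 1 to compound 3 (beyond the scatter). Nothing available explains this difference. Still open, going by these compounds, is how an unsubstituted phenyl or a phenyl carrying only a methoxy or only a methyl group would compare. On these data alone, whether an amine or a carboxylic acid would be tolerated on this phenyl group also remains open.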